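The source may report more compounds than this note shows. Statements on the series, on what has been measured and on what is new or still open speak of the compounds shown alone.

Measured compounds in an assay on isolated protein for binding affinity to adenosine receptor A3 (Homo sapiens); on this read-out higher numbers stand for weaker inhibition and lower numbers for stronger inhibition:
- compound 1 `CNC(=O)[C@]12C[C@@H]1[C@@H](n1cnc3c(NCc4ccc(N=[N+]=[N-])cc4)nc(C#Cc4ccc(F)c(F)c4)nc31)[C@H](O)[C@@H]2O`: for compound 1 the read-out reaches only the assay limit, >= 99 nM.
- compound 2 `CCOC(=O)[C@]12C[C@@H]1[C@@H](n1ccc3c(NCCCc4ccc(OC)c(O)c4)nc(C#Cc4ccccc4)nc31)[C@H](O)[C@@H]2O`: for compound 2 the read-out likewise reaches only the assay limit, >= 99 nM.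

Compound 2 therefore stands at the limit with no number of its own, and compound 1 stands at the same place; both values sit at the limit of >= 99 nM in this assay, at which 2 of the 2 values shown sit. Nothing on this read-out separates the two compounds.

Compound 3 `CCOC(=O)[C@]12C[C@@H]1[C@@H](n1ccc3c(NCCCc4ccc(OC)c(O)c4)nc(C#Cc4ccc(Cl)s4)nc31)[C@H](O)[C@@H]2O` differs from compound 2 in one place: 5-chlorothiophen-2-yl in place of phenyl on a triple-bonded carbon. Going by the values given here, no step between measured compounds is known here, so the change has no precedent on which to lean. Since compound 2 gives only a limit, compound 3 is expected most likely to sit at or beyond that same limit, and the expected step is none beyond the scatter, with a numerical value rather unlikely to be returned. The estimated step is a step that the limit leaves unreadable from compound 2 to compound 3. For compound 3 the estimate in this assay is 300 nM, expected within 80 nM to 3000 nM.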

Compound 3, inhibition constant: >= 99 nM
Compound 3: a limit, no number (the forecaster's own chance of this, stated with the estimate: 70%); the middle value lies beyond the limit too.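

In this assay compound 3 gives >= 99 nM, which is a limit of the assay. With compound 2 also at a limit, no step can be read between compound 2 and compound 3: the limit of >= 99 nM in this assay, at which 3 of the 3 values shown sit.

The compounds shown leave open how far each lies beyond the limit, and whether 5-chlorothiophen-2-yl in place of phenyl changes the read-out at all.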